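Swapping a fluorophenyl for a thiophene on the shared core

The compounds below may be only part of what the source reports. "The series", "measured", "known", "first", "only" and "open" are said of these compounds alone.

Compound 1 `O=C(O)c1csc(-n2nc(-c3ccccc3)c3cc(F)ccc32)n1`: 80 nM
Compound 2 `O=C(O)c1csc(-n2nc(-c3ccccc3)c3ccc(O)cc32)n1`: 140 nM
Compound 3 `O=C(O)c1csc(-n2nc(-c3ccc(F)cc3)c3ccccc32)n1`: 4.5 nM

Of the compounds shown here, three sharing one core have been tested in an assay on isolated protein for antagonist activity at prostaglandin E2 receptor EP1 subtype (Homo sapiens), read by reporter gene assay; a higher number here means a weaker inhibitor, a lower number a stronger inhibitor. Compound 3 gives the lowest number, and its gaps to compound 1 and to compound 2 both lie beyond the scatter, so among the three it is the strongest inhibitor in this assay.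

Compound 4 `O=C(O)c1csc(-n2nc(-c3ccsc3)c3ccccc32)n1` has not been measured. Compared with compound 3, it carries thiophen-3-yl in place of 4-fluorophenyl on an aromatic carbon. Among the measured compounds shown here, no measured pair shows this exact exchange, so the size of the step rests on judgement alone. A modest loss of potency seems the most likely outcome, though a result close to compound 3 cannot be excluded.

For compound 4 the expected value is 20 nM, with a range from 5 nM to 80 nM, an estimated step of a 4.4-fold higher number from compound 3 to compound 4 (0.65 log units; beyond the scatter).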

Compound 4, half-maximal inhibitory concentration: 30 nM
For compound 4 the middle estimate is 1.5-fold (0.18 log units) below the measured one; the range from low to high includes it.
By their numbers in this assay, from the lowest: compound 3; then compound 4; then compounds 1 and 2 (each within the scatter of the next).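

In this assay, thiophen-3-yl in place of 4-fluorophenyl on this aromatic carbon gives a 6.7-fold higher number from compound 3 to compound 4 (0.82 log units; beyond the scatter) and so costs some potency without abolishing it. Among the compounds shown here, this is the first direct view of this position, as the earlier compounds offered no pair differing only here. Nothing in the data shown explains the size of this step.

From the compounds shown here alone, it remains open whether the loss follows from the change of ring or from the missing fluorine. How a pyridin-3-yl or thiophen-2-yl group would behave on this carbon is also unknown.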